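The source may report more compounds than this note shows. Statements on the series, on what has been measured and on what is new or still open speak of the compounds shown alone.

Compound 2 `COc1ccc2nc(C)cc(OCC(=O)Nc3c(C)cccc3C)c2c1` and compound 1 `COc1ccc2nc(C)cc(OC3CCN(c4ccccc4)C3=O)c2c1` share a core and have both been run in a physicochemical assay for lipophilicity, read by HPLC, in phosphate buffer, measured as chromatographic lipophilicity, at pH 7.4; on this read-out lower numbers stand for lower lipophilicity and higher numbers for higher lipophilicity. In that test compound 2 gives 4.55, while compound 1 gives 4.99, so compound 2 stands lower of the two, with the gap to compound 1 beyond the usual scatter. Compound 3 `COc1ccc2nc(C)cc(OCC(=O)Nc3c(C)cncc3C)c2c1` has not yet been measured. It differs from compound 2 in one place: 3,5-dimethylpyridin-4-yl in place of 2,6-dimethylphenyl on an amide-type nitrogen. A step toward lower lipophilicity in this assay is expected, of about a number 1.15 log units lower from compound 2 to compound 3 (beyond the scatter). Compound 3 is therefore estimated at 3.4, most likely between 2.8 and 4.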

Compound 3, distribution coefficient: 3.01
Beside the measured number, compound 3's estimate is 0.39 log units above it; measured number inside the range.
By their numbers in this assay, from the lowest: compound 3; then compound 2; then compound 1.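

In this assay, the step is large: a number 1.54 log units lower from compound 2 to compound 3 (beyond the scatter). This position on the amide-type nitrogen therefore responds strongly to a small edit, as the group keeps its heavy-atom count while one ring carbon becomes nitrogen and one hydrogen-bond acceptor is gained. Nothing measured here accounts for the size of this step. Still open, going by these compounds, is whether a similar step would appear with a 3,5-dimethylpyridin-4-yl group in a different amide, such as that of compound 1. On these data alone, how an amine or a carboxylic acid on this nitrogen-bound ring would read also remains unknown.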